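This account rests on a few compounds, and the source may have more. Where it says the series, first, only, none or still open, it means among the compounds named here.

Measured so far:
compound 1 `Nc1nc(N)c2c(-c3ccsc3)cn([C@@H]3O[C@H](CO)[C@@H](O)[C@H]3O)c2n1`: > 100000 nM
compound 2 `C#Cc1cn([C@@H]2O[C@H](CO)[C@@H](O)[C@H]2O)c2ncnc(OC)c12`: 98400 nM

Both compounds were tested in an ADME assay on BJ cells (Homo sapiens), read by MTT assay, with a stated time of 72 h; on this read-out lower numbers stand for stronger inhibition and higher numbers for weaker inhibition. Compound 1 gives only a limit of the assay, > 100000 nM, and no number; it is one of the values described by the limit of > 100000 nM in this assay, at which 1 of the 2 values shown sits. Compound 2, which shares the sugar but carries a different core, gives 98400 nM in this assay. Among the compounds with values here, no step between the two measured compounds can be drawn, since they differ in more than one place.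

Compound 3 `Nc1nc(N)c2c(-c3ccoc3)cn([C@@H]3O[C@H](CO)[C@@H](O)[C@H]3O)c2n1` is the compound still to be measured. It differs from compound 1 in one place: furan-3-yl in place of thiophen-3-yl on an aromatic carbon. With compound 1 already at a limit, the expected step of a number no higher from compound 1 to compound 3 (the limit leaves the size open) is none beyond the scatter. Compound 3 is therefore expected to give 100000 nM in this assay, with a range from 30000 nM to 300000 nM, and most likely the assay will again report only a limit for compound 3.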

Compound 3, half-maximal inhibitory concentration: > 100000 nM
Compound 3: no number, only a limit; the forecaster's own chance of this, stated with the estimate: 70%; the middle value sits exactly at the limit.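

Compound 1 and compound 3 each give only a limit in this assay, not a number, so no step between them can be read: the limit of > 100000 nM in this assay, at which 2 of the 3 values shown sit.

The compounds shown leave open whether furan-3-yl and thiophen-3-yl differ at all in this assay.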